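Swapping a nitro-bearing ring for a short chain

The source may hold more compounds than are shown below. What is called first, only, known or untested is meant among the compounds shown, and "the series" means these compounds.

Measured so far:
compound 1, `COc1ccc(Cn2c(=O)n(C3OC(CO)[C@@H](O)[C@H]3O)c3nc(N)nc(O)c32)cc1`, 44%
compound 2, `Nc1nc(O)c2c(n1)n(C1OC(CO)[C@@H](O)[C@H]1O)c(=O)n2Cc1ccc([N+](=O)[O-])cc1`, 147%

In a functional assay on the whole organism (B cells) with Mus musculus as the target (on this read-out higher numbers stand for larger maximal responses and lower numbers for smaller maximal responses), compound 2 stands highest of the two numbers, with compound 1 a large step below it: a number 103 percentage points higher from compound 1 to compound 2 (beyond the scatter). Compound 3, `CCCCn1c(=O)n(C2OC(CO)[C@@H](O)[C@H]2O)c2nc(N)nc(O)c21`, is not yet measured. The change is propyl in place of 4-nitrophenyl on a saturated chain carbon bound to an aromatic nitrogen. Among the compounds with values here, no measured step covers the loss of the whole ring; the one step known concerns only a group on that ring, so it gives limited guidance. Within the data shown here, because the only comparison, a number 103 percentage points higher from compound 1 to compound 2 (beyond the scatter), shows a strong dependence on what sits on the ring, a drop is expected, estimated at a number 87 percentage points lower from compound 2 to compound 3 (beyond the scatter). Compound 3 is therefore expected to give 60%, within 20% to 130%.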

Compound 3, largest response reached (reported as maximal response), in percent of the reference or control that the assay uses: 86%
Compound 3: middle estimate off by 26 percentage points, on the low side; low and high end bracket the measured number.
By their numbers in this assay, from the lowest: compound 1; then compound 3; then compound 2.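

Losing the ring does not move the response in one direction in this assay: the change gives a number 61 percentage points lower from compound 2 to compound 3 (beyond the scatter), yet a number 42 percentage points higher from compound 1 to compound 3 (beyond the scatter). The butyl chain therefore falls between the two benzyl groups, so whether a ring at this place beats a plain chain depends on the group that ring carries. Nothing available explains this difference. Still open, going by these compounds, is how an unsubstituted benzyl group would compare with butyl, and whether a longer chain such as hexyl would raise or lower the response.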